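The source may hold more compounds than are shown below. What is called first, only, known or untested is meant among the compounds shown, and "the series" means these compounds.

Measured so far in a functional assay on PC-3 cells (Homo sapiens) for cytotoxicity, read by MTT assay, with a stated time of 72 h; on this read-out higher numbers stand for weaker inhibition and lower numbers for stronger inhibition:
- compound 1 `CNC(=O)c1cc(Oc2ccc(NC(=O)c3cc(-c4ccc(Br)cc4)ncn3)cc2)ccn1`: > 100000 nM
- compound 2 `CNC(=O)c1cc(Oc2ccc(NC(=O)c3cc(-c4ccc(F)cc4)ncn3)cc2)ccn1`: > 100000 nM

Both entries are limits of the assay and not numbers. Compound 2 therefore has no exact position in the series, and it shares (the limit of > 100000 nM in this assay, at which 2 of the 2 values shown sit).

Compound 3 `CNC(=O)c1cc(Oc2ccc(NC(=O)c3cc(-c4ccc(OC)cc4)ncn3)cc2)ccn1` differs from compound 2 as follows: methoxy in place of fluoro on an aromatic carbon. In words, this is methoxy in place of fluoro on an aromatic carbon, para to a large group.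

Among the measured compounds shown here, only one measured step bears on this change: a step that the two limits leave unreadable from compound 1 to compound 2. It gives no size to carry over, so the expectation rests on that step and on (the limit of > 100000 nM in this assay, at which 2 of the 2 values shown sit). No step beyond the scatter is expected in this assay, and no direction can be assigned. The expected step is a number no higher from compound 2 to compound 3 (the limit leaves the size open). For compound 3 the estimated value is 100000 nM, with an expected range from 30000 nM to 200000 nM.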

Compound 3, half-maximal inhibitory concentration: 38800 nM
For compound 3 the middle estimate is 2.6-fold (0.41 log units) above the measured one, and the stated range covers the measured number.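

In this assay, the place para to a large group now responds to substitution: 4-fluorophenyl to 4-methoxyphenyl gives an at least 2.5-fold lower number from compound 2 to compound 3 (0.41 log units; beyond the scatter). Methoxy in place of bromo at the same place gives an at least 2.5-fold lower number from compound 1 to compound 3 (0.41 log units; beyond the scatter), so methoxy separates from both halogens in this series. The step between the two halogen compounds cannot be read, and compound 3 is the only one of the three with a number and not a limit: the limit of > 100000 nM in this assay, at which 2 of the 3 values shown sit.

Going by these compounds, both readable steps start from limits, so their true sizes remain open, and a single methoxy compound cannot show whether the oxygen or the whole group carries the change. A hydroxyl, an amine or a longer chain such as ethoxy at this place would test how far the step extends.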